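The source may hold more compounds than are shown below. What is called first, only, known or untested is meant among the compounds shown, and "the series" means these compounds.

Compound 1 `[N-]=[N+]=N[C@@H]1C(n2ccc(=O)[nH]c2=O)[Se][C@H](CO)[C@H]1O` and compound 2 `O=c1ccn(C2[Se][C@H](CO)[C@@H](O)[C@@H]2O)c(=O)[nH]1` share one core and differ only by hydroxy in place of azido on a saturated ring carbon. In a functional assay on SNU-638 cells (Homo sapiens) for cytotoxicity, read by sulforhodamine B assay (a lower number here means a stronger inhibitor, a higher number a weaker inhibitor), compound 1 gives only a limit, > 100000 nM. Compound 2 likewise gives only a limit in this assay, > 100000 nM. The step that the two limits leave unreadable from compound 1 to compound 2 cannot be read because both values sit at the limit of > 100000 nM in this assay, at which 2 of the 3 values shown sit. Compound 3 `[N-]=[N+]=N[C@@H]1C(n2ccc(N)nc2=O)[Se][C@H](CO)[C@H]1O` carries a different core; the difference between the cores of compound 1 and compound 3 is not broken down here. In this assay, within the data shown here, compound 3 gives 85200 nM, the only number among the three. Compound 4 `Nc1ccn(C2[Se][C@H](CO)[C@@H](O)[C@@H]2O)c(=O)n1` has not yet been measured and differs from compound 3 by hydroxy in place of azido on a saturated ring carbon, the same change as that from compound 1 to compound 2. Among the measured compounds shown here, since the only measured example of this change is a step that the two limits leave unreadable from compound 1 to compound 2, its size remains unknown. Compound 3 is a weak inhibitor whose value 85200 nM lies close to the top of the measurable range, so compound 4 is expected to stay in that region, with an expected step of a 1.2-fold higher number from compound 3 to compound 4 (0.07 log units; within the scatter). The value expected for compound 4 is 100000 nM, within an expected range from 40000 nM to 300000 nM, and quite possibly only a limit will be reported.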

Compound 4, half-maximal inhibitory concentration: 4720 nM
Compound 4: middle estimate off by 21-fold (1.33 log units), on the high side; the measured number lies below the stated range.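

On the core of compound 3, putting hydroxy in place of azido on a saturated ring carbon gives an 18-fold lower number from compound 3 to compound 4 (1.26 log units; beyond the scatter) in this assay, so in this series the change can have a large effect on the measured number. On the core of compound 1, the same change cannot be read, because neither compound there gives a number, only a limit of the assay: the limit of > 100000 nM in this assay, at which 2 of the 4 values shown sit. One readable step on one core therefore shows what the change did to compound 3, but it does not show that a step of this size, or any step at all, carries over to the core of compound 1.

The compounds shown leave open how other groups on the same ring carbon, such as a fluorine atom, a methoxy group or a primary amine, would compare with hydroxy and azido in this assay. They also leave open whether hydroxy in place of azido would give a similar step on any further core.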